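Estimating compound 4 from three close neighbours

The compounds below may be only part of what the source reports. "The series", "measured", "known", "first", "only" and "open" are said of these compounds alone.

Compound 1 `COc1ccc(N(C)c2nc(C)nc3ccccc23)cc1OCCC[Se]C#N`: 382 nM
Compound 2 `COc1ccc(N(C)c2nc(C)nc3ccccc23)cc1C(=O)OCC[Se]C#N`: 353 nM
Compound 3 `COc1ccc(N(C)c2nc(C)nc3ccccc23)cc1C(=O)OCCC[Se]C#N`: 250 nM

These three values come from a functional assay on A549 cells (Homo sapiens) for inhibition, read by MTT assay, with a stated time of 48 h; on this read-out lower numbers stand for stronger inhibition and higher numbers for weaker inhibition. Compound 3 stands close to the other two compounds, and nothing separates the three beyond the usual scatter of repeated measurements.

The next compound is compound 4 `COc1ccc(N(C)c2nc(C)nc3ccccc23)cc1C(=O)NCC[Se]C#N`. Its difference from compound 3 is a group of 6 heavy atoms (3 carbon, 2 nitrogen, 1 selenium; no ring) in place of a group of 7 heavy atoms (4 carbon, 1 nitrogen, 1 oxygen, 1 selenium; no ring), on a carbonyl carbon. The swap sits on a carbonyl carbon whose other neighbours are: aromatic carbon.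

Going by the values given here, three measured steps bear on this change. The closest is a 1.4-fold lower number from compound 2 to compound 3 (0.15 log units; within the scatter), which changes only the chain. The other two are a 1.1-fold lower number from compound 1 to compound 2 (0.03 log units; within the scatter) and a 1.5-fold lower number from compound 1 to compound 3 (0.18 log units; within the scatter). All three are small and within the scatter, so these compounds have so far tolerated changes to this side group. None of the steps, however, makes the same swap as this one, so the data offer no direct guide and give no firm direction. A larger move therefore cannot be ruled out, and the range must stay wide.

No step beyond the scatter is expected in this assay. The estimated step is a 1.4-fold higher number from compound 3 to compound 4 (0.15 log units; within the scatter). For compound 4 the estimated value is 350 nM, with an expected range from 130 nM to 950 nM.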

Compound 4, half-maximal inhibitory concentration: 187 nM
For compound 4 the middle estimate is 1.9-fold (0.27 log units) above the measured one, within the range that was stated.
By their numbers in this assay, from the lowest: compounds 4, 3, 2 and 1 (each within the scatter of the next, the first and the last beyond it).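

In this assay the ester on the carbonyl carbon is now exchanged directly for an amide, which adds a hydrogen-bond donor to the side group: with the chain kept, this gives a 1.9-fold lower number from compound 2 to compound 4 (0.28 log units; within the scatter) and, with a shorter chain as well, a 1.3-fold lower number from compound 3 to compound 4 (0.13 log units; within the scatter) and the amide therefore stands on a par with both esters at this position. Set against the ether of compound 1, the amide of compound 4 gives a 2.0-fold lower number from compound 1 to compound 4 (0.31 log units; beyond the scatter) and this is the first step among these compounds to pass beyond the scatter, though only modestly. No measurement here accounts for these numbers.

Going by these compounds, what a methyl group on the amide nitrogen would do remains open, which leaves the role of the amide hydrogen unsettled, and so does the effect of a longer chain on the amide, a change that would mirror the step between the two esters. Also open is whether the selenium-bearing nitrile end is needed at all, as every compound shown carries it, and a simple carboxylic acid or amine in its place would test that.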